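The source may hold more compounds than are shown below. What is called first, only, known or untested is meant among the compounds shown, and "the series" means these compounds.

Of the compounds shown here, three have been measured in a functional assay for inhibition of sodium/hydrogen exchanger (Oryctolagus cuniculus); a higher number here means a weaker inhibitor, a lower number a stronger inhibitor. Compound 1 `Cc1c(C(=O)N=C(N)N)cc(S(C)(=O)=O)c(Cl)c1Cl` gives 29 nM. Compound 2 `Cc1c(C(=O)N=C(N)N)ccc(Cl)c1S(C)(=O)=O` gives 1300 nM. Compound 3 `Cc1cc(-c2cc(Cl)cc(Cl)c2)c(S(C)(=O)=O)cc1C(=O)N=C(N)N` gives 130 nM. Of these three numbers compound 3 holds the second highest: its nearest neighbour is compound 1, which lies lower by a gap beyond the scatter, and the furthest is compound 2, which lies higher by a gap also beyond the scatter.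

Compound 4 `Cc1cc(Oc2ccccc2)c(S(C)(=O)=O)cc1C(=O)N=C(N)N` has not yet been measured in this assay. It differs from compound 3 in one place: phenoxy in place of 3,5-dichlorophenyl on an aromatic carbon. Going by the values given here, no measured pair shows this change, so nothing in the data tells its direction.

The group that enters and the group that leaves are of similar size, each built on one six-membered aromatic ring of carbon only. Compound 4 is therefore expected to stay near compound 3, with a step of a 1.9-fold higher number from compound 3 to compound 4 (0.28 log units; within the scatter) that may be a modest weakening or none beyond the scatter. The estimate for compound 4 in this assay is 250 nM, within a range of 80 nM to 800 nM.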

Compound 4, half-maximal inhibitory concentration: 10 nM
Compound 4: middle estimate off by 25-fold (1.40 log units), on the high side, outside the stated range (below it).
By their numbers in this assay, from the lowest: compound 4; then compound 1; then compound 3; then compound 2.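

In this assay, phenoxy in place of 3,5-dichlorophenyl on the aromatic carbon ortho to a methylsulfonyl group gives a 13-fold lower number from compound 3 to compound 4 (1.11 log units; beyond the scatter). This position therefore does not treat these two groups alike, even though each is built on one six-membered aromatic ring of carbon only, and exchanging this one group moves the number well beyond the scatter. Nothing measured here accounts for the size of this step. The compounds shown leave open whether the step follows the oxygen that enters or the two chlorines that leave, a question that a plain phenyl or a 3,5-dichlorophenoxy group on this carbon would help to separate. They also leave open how an amine or a longer chain at this place would read.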